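Ether series on the shared core: weaker, stronger, or no change

The compounds below may be only part of what the source reports. "The series", "measured", "known", "first", "only" and "open" are said of these compounds alone.

compound 1, `N[C@]1(C(=O)O)[C@H]2[C@@H](C[C@H]1OCCCc1ccccc1)[C@]2(F)C(=O)O`, 9.83 nM
compound 2, `N[C@]1(C(=O)O)[C@H]2[C@@H](C[C@H]1OCc1cccc(Oc3ccccc3)c1)[C@]2(F)C(=O)O`, 7.15 nM

Of the compounds shown here, two have been measured in an assay on CHO cells for binding affinity to metabotropic glutamate receptor 2 (Rattus norvegicus); a higher number here means a weaker inhibitor, a lower number a stronger inhibitor. Compound 1 gives 9.83 nM and compound 2 gives 7.15 nM; compound 1 has the higher of the two numbers, but the gap to compound 2 lies within the scatter, so the two cannot be told apart.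

Compound 3, `N[C@]1(C(=O)O)[C@H]2[C@@H](C[C@H]1OCc1ccc(F)c(F)c1)[C@]2(F)C(=O)O`, is not yet measured. It differs from compound 1 in one place: 3,4-difluorophenyl in place of phenethyl on a saturated chain carbon bound to an oxygen on a saturated carbon. Among the compounds with values here, no measured pair shows what such a change does on this core, so the step from compound 1 to compound 3 in this assay can only be guessed from compound 1 at 9.83 nM and compound 2 at 7.15 nM, both of which sit close together. A step of no more than the scatter is expected, a 1.4-fold higher number from compound 1 to compound 3 (0.15 log units; within the scatter), if anything toward a slightly higher number. Compound 3 is therefore estimated at 14 nM, with a range from 5 nM to 45 nM.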

Compound 3, inhibition constant: 2.27 nM
Estimate against measurement, compound 3: 6.2-fold (0.79 log units) above; the measured number lies below the stated range.
By their numbers in this assay, from the lowest: compound 3; then compounds 2 and 1 (each within the scatter of the next).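

In this assay, within the data shown here, a 4.3-fold lower number from compound 1 to compound 3 (0.64 log units; beyond the scatter) gives the first step beyond the scatter on the shared core, so the group on the saturated chain carbon bound to an oxygen on a saturated carbon can change the number. Phenethyl and 3,4-difluorophenyl both count 8 heavy atoms, one six-membered aromatic ring of carbon only and 0 hydrogen-bond donors or acceptors, so these counts do not separate the two groups; the entering group differs in its 2 fluorine atoms. Nothing available explains the step.

The compounds shown leave open whether an unsubstituted phenyl, a single fluorine or a chlorine in this place would give a similar number. Also open, as far as these compounds go, is what a longer chain carrying 3,4-difluorophenyl, or an amine on that group, would do.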